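The source may report more compounds than this note shows. Statements on the series, on what has been measured and on what is new or still open speak of the compounds shown alone.

Compound 1: `Fc1cccc(NC(=S)N/N=C/c2ccc3ccccc3n2)c1` — 70100 nM
Compound 2: `S=C(N/N=C/c1ccc2ccccc2n1)Nc1cccc(Br)c1` — 70000 nM
Compound 3: `S=C(N/N=C/c1ccc2ccccc2n1)Nc1ccccc1Br` — > 100000 nM
Compound 4: `S=C(NCc1ccccc1)N/N=C/c1ccc2ccccc2n1` — not yet measured

All three measured compounds were tested in a functional assay on HeLa cells (Homo sapiens) for antiproliferative activity, read by sulforhodamine B assay, with a stated time of 72 h; on this read-out higher numbers stand for weaker inhibition and lower numbers for stronger inhibition. Compound 1 gives 70100 nM and compound 2 gives 70000 nM, two numbers that sit within the scatter of each other. For compound 3 the reading is a limit of the assay rather than a number, > 100000 nM, so only a floor is known, and this is the limit of > 100000 nM in this assay, at which 1 of the 3 values shown sits. The steps among the measured compounds are a 1.0-fold lower number from compound 1 to compound 2 (0.00 log units; within the scatter), an at least 1.4-fold higher number from compound 1 to compound 3 (0.15 log units; that floor lies within the scatter) and an at least 1.4-fold higher number from compound 2 to compound 3 (0.15 log units; that floor lies within the scatter); none of them goes beyond the scatter, so the three aryl variants all stand in the same weak region.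

Compound 4 differs from compound 3 in one place: benzyl in place of 2-bromophenyl on an amide-type nitrogen. Among the compounds with values here, no measured step exchanges an aryl group for a benzyl group, so none bears directly on this change; the only guidance is that the changes tried so far left the numbers flat. The step from compound 3 to compound 4 is therefore expected to be a number no higher from compound 3 to compound 4 (the limit leaves the size open), within the scatter. Compound 4 is estimated at 100000 nM, with a range from 40000 nM to 300000 nM, and a real chance that this assay again reports only a limit.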

Compound 4, half-maximal inhibitory concentration: 62800 nM
Compound 4: the middle estimate sits 1.6-fold (0.20 log units) above what was measured, and the stated range covers the measured number.
By their numbers in this assay, from the lowest: compounds 4, 2 and 1 (each within the scatter of the next). At a limit, above all of these: compound 3.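

Replacing the aryl group on this amide-type nitrogen with benzyl, which carries no halogen, does not separate compound 4 from the halogen-bearing aryl compounds in this assay (a 1.1-fold lower number from compound 2 to compound 4 (0.05 log units; within the scatter); a 1.1-fold lower number from compound 1 to compound 4 (0.05 log units; within the scatter)). Going by these compounds, the comparison with compound 3 also shows no difference beyond the scatter, and its true size stays open (an at least 1.5-fold lower number from compound 3 to compound 4 (0.20 log units; that floor lies within the scatter)). Within the data shown here, compound 3 remains the only compound here at a limit rather than a number: the limit of > 100000 nM in this assay, at which 1 of the 4 values shown sits.

On these data alone, whether any group at this nitrogen can move the number beyond the scatter remains open, for example a longer chain such as 2-phenylethyl, or a benzyl group bearing an amine or a carboxylic acid. The compounds shown also say nothing about changes to the shared core.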